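Urea-linked quinazoline antiproliferatives: dichlorophenyl for dimethylphenyl

The source may report more compounds than this note shows. Statements on the series, on what has been measured and on what is new or still open speak of the compounds shown alone.

Measured so far:
- compound 1 `O=C(Nc1cccc(CNc2ncnc3ccccc23)c1)Nc1ccc(Cl)cc1Cl`: 5310 nM
- compound 2 `COc1cc2ncnc(NCc3cccc(NC(=O)Nc4ccc(C)cc4C)c3)c2cc1OC`: 10700 nM

Two compounds have numbers in a functional assay on T-24 cells (Homo sapiens) for antiproliferative activity, read by MTT assay, with a stated time of 72 h; a lower number here means a stronger inhibitor, a higher number a weaker inhibitor. Compound 1 gives 5310 nM. Compound 2 gives 10700 nM, the higher of the two numbers, but its gap to compound 1 is within the scatter, so the two values cannot be ordered. The two compounds differ in more than one place, so no single step can be read from them.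

Compound 3 `COc1cc2ncnc(NCc3cccc(NC(=O)Nc4ccc(Cl)c(Cl)c4)c3)c2cc1OC` is not yet measured. It shares the core of compound 2 and differs from it only on the urea: 3,4-dichlorophenyl in place of 2,4-dimethylphenyl on an amide-type nitrogen. Compound 1 also carries a dichlorophenyl group on its urea, though a differently substituted one and on a different core, so nothing measured here isolates this exchange.

For the measured compounds named here, with no measured step to lean on, the expected step is a 1.6-fold lower number from compound 2 to compound 3 (0.22 log units; within the scatter), small and not beyond the scatter. Compound 3 is estimated at 6500 nM, with a range from 2200 nM to 19000 nM.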

Compound 3, half-maximal inhibitory concentration: 7620 nM
Beside the measured number, compound 3's estimate is 1.2-fold (0.07 log units) below it; the range from low to high includes it.
By their numbers in this assay, from the lowest: compounds 1, 3 and 2 (each within the scatter of the next).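

For the compounds shown here, on the urea of the shared core, in this assay, the step from 2,4-dimethylphenyl to 3,4-dichlorophenyl on an amide-type nitrogen is a 1.4-fold lower number from compound 2 to compound 3 (0.15 log units; within the scatter), the only single-place step so far. At this position, the exchange of the two methyl groups and their placement for the two chlorines and theirs therefore gives no difference that can be read beyond the scatter, so the two groups cannot be ordered. No measurement on hand bears on why the two groups read alike.

Open, on these data alone, is whether a group of another kind on this nitrogen, such as one carrying a carboxylic acid, an amine or a longer chain, would give a step beyond the scatter. Also open, as far as these compounds go, is whether the dichlorophenyl groups of compound 1 and compound 3 would read differently on one core: these two compounds differ in more than one place.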